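Swapping the aryl group on the cyclopropane of a GPR88 agonist

The source may report more compounds than this note shows. Statements on the series, on what has been measured and on what is new or still open speak of the compounds shown alone.

Of the compounds shown here, three sharing one core have been measured in a functional assay for agonist activity at G protein-coupled receptor 88 (Homo sapiens), read by HTRF and cAMP accumulation; on this read-out lower numbers stand for an effect already at smaller amounts and higher numbers for an effect only at larger amounts of compound. Compound 1 `CC[C@H](C)[C@H](N)CN(C(=O)[C@@H]1C[C@H]1c1cccc(OC)c1)c1ccc(-c2ccccc2)cc1` gives 3000 nM. Compound 2 `CC[C@H](C)[C@H](N)CN(C(=O)[C@@H]1C[C@H]1c1cccc(C#N)c1)c1ccc(-c2ccccc2)cc1`, which carries a nitrile in place of the methoxy group, gives 1600 nM. Compound 3 `CC[C@H](C)[C@H](N)CN(C(=O)[C@@H]1C[C@H]1c1ccncc1)c1ccc(-c2ccccc2)cc1` gives 1500 nM. Compound 3 thus has the lowest number of the three, but its steps to compound 2 and to compound 1 both lie within the scatter, with a 2.0-fold lower number from compound 1 to compound 3 (0.30 log units; within the scatter) and a 1.1-fold lower number from compound 2 to compound 3 (0.03 log units; within the scatter), so no ordering among them can be claimed.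

Compound 4 `CC[C@H](C)[C@H](N)CN(C(=O)[C@@H]1C[C@H]1c1cccs1)c1ccc(-c2ccccc2)cc1` has not yet been measured. It differs from compound 3 by thiophen-2-yl in place of pyridin-4-yl on a saturated ring carbon. Within the data shown here, the steps that bear on this change are the earlier exchanges of the aromatic group on the same ring carbon, a 2.0-fold lower number from compound 1 to compound 3 (0.30 log units; within the scatter) and a 1.1-fold lower number from compound 2 to compound 3 (0.03 log units; within the scatter), both within the scatter. On that basis no step beyond the scatter is expected in this assay, and no change at the digits printed from compound 3 to compound 4 (within the scatter) is the estimated step. Compound 4 is expected to give 1500 nM, with a range of 600 nM to 4000 nM.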

Compound 4, half-maximal effective concentration: 360 nM
Compound 4: the middle estimate sits 4.2-fold (0.62 log units) above what was measured; measured number outside the range, below it.
By their numbers in this assay, from the lowest: compound 4; then compounds 3, 2 and 1 (each within the scatter of the next).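

In this assay, among these compounds, thiophen-2-yl is the first group on this saturated ring carbon to move the number beyond the scatter (a 4.2-fold lower number from compound 3 to compound 4 (0.62 log units; beyond the scatter); a 4.4-fold lower number from compound 2 to compound 4 (0.65 log units; beyond the scatter); an 8.3-fold lower number from compound 1 to compound 4 (0.92 log units; beyond the scatter)). The position therefore responds to the group it carries, and among the compounds shown, the five-membered thiophen-2-yl stands apart from the six-membered aromatic groups of compounds 1, 2 and 3, which cannot be told apart from one another. No measurement at hand accounts for this step.

With only one five-membered ring among the compounds shown, ring size cannot be separated from the sulfur atom or from the way the ring is attached. The compounds shown do not say how furan-2-yl or thiophen-3-yl would behave here, or what a methyl group or a chlorine atom on the thiophene would do.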